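Iodo to methoxy on the aryl group of compound 3

The source may hold more compounds than are shown below. What is called first, only, known or untested is meant among the compounds shown, and "the series" means these compounds.

Values in a functional assay (muscle tissue) with Cavia porcellus as the target (a lower number here means that less compound is needed, a higher number that more compound is needed for the effect), so far
- compound 1 `COC(=O)C1=C(C)N=C(C)/C(=C(\O)OC)C1c1cccc(O)c1` gives 1000 nM
- compound 2 `COC(=O)C1=C(C)N=C(C)/C(=C(\O)OC)C1c1ccc(F)cc1` gives 129 nM
- compound 3 `COC(=O)C1=C(C)N=C(C)/C(=C(\O)OC)C1c1ccccc1I` gives 46.8 nM

Compound 3 has the lowest number of the three, and compound 2 lies nearest to it. Compound 4 `COC(=O)C1=C(C)N=C(C)/C(=C(\O)OC)C1c1ccccc1OC` carries methoxy in place of iodo on an aromatic carbon and is still unmeasured. The nearest evidence is a 2.8-fold lower number from compound 2 to compound 3 (0.44 log units; beyond the scatter) and, larger, a 21-fold lower number from compound 1 to compound 3 (1.33 log units; beyond the scatter) but each of these steps also moves the group on the ring. Among the compounds with values here, no measured step exchanges groups at this place. Compound 3 at 46.8 nM already sits lowest, so a modest step to a higher number is expected in this assay for the new group. The estimate means a 2.8-fold higher number from compound 3 to compound 4 (0.44 log units; beyond the scatter) as the expected step. Compound 4 is estimated at 130 nM with 40 nM to 420 nM as the expected range.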

Compound 4, half-maximal effective concentration: 57.5 nM
Compound 4: middle estimate off by 2.3-fold (0.35 log units), on the high side, within the range that was stated.
By their numbers in this assay, from the lowest: compounds 3 and 4 (each within the scatter of the next); then compound 2; then compound 1.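

In this assay, methoxy in place of iodo on an aromatic carbon ortho to a large group gives a 1.2-fold higher number from compound 3 to compound 4 (0.09 log units; within the scatter), so this exchange does not separate the two groups, although methoxy brings a hydrogen-bond acceptor that iodo lacks. The 2-methoxyphenyl group also keeps its distance from the other aryl groups, with a 2.2-fold lower number from compound 2 to compound 4 (0.35 log units; beyond the scatter) and a 17-fold lower number from compound 1 to compound 4 (1.24 log units; beyond the scatter). No available data explain this result. Still open, on these data alone, is whether an amine, a carboxylic acid or a longer chain at this place would fit the same range. Also open, as far as these compounds go, is how methoxy would read elsewhere on the aryl group.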